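The source may hold more compounds than are shown below. What is called first, only, known or untested is meant among the compounds shown, and "the series" means these compounds.

Measured in a functional assay (Mus musculus) for inhibition, with a stated time of 5 days; a lower number here means a stronger inhibitor, a higher number a weaker inhibitor:
- Compound 1 `O=C(O)/C=C/c1cn(-c2ccc(O)cc2)nc1-c1cccc(O)c1`: > 100000 nM (a limit, not a number)
- Compound 2 `CCOC(=O)/C=C/c1cn(-c2ccc(O)cc2)nc1-c1cccc(O)c1`: 14000 nM
- Compound 3 `O=Cc1cn(-c2ccc(O)cc2)nc1-c1cccc(O)c1`: 42000 nM

Compound 1 is the weakest of the three, and its result is only a limit: the limit of > 100000 nM in this assay, at which 1 of the 3 values shown sits. Compound 4 `O=C(O)/C=C/c1cn(-c2ccc(O)cc2)nc1-c1ccccc1` keeps the core of compound 1 but differs in one group: hydrogen in place of hydroxy on an aromatic carbon. This is hydrogen in place of hydroxy on an aromatic carbon, so 3-hydroxyphenyl becomes phenyl.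

Among the compounds with values here, no measured step touches this group. The steps of an at least 7.1-fold lower number from compound 1 to compound 2 (0.85 log units; beyond the scatter), an at least 2.3-fold lower number from compound 1 to compound 3 (0.37 log units; beyond the scatter) and a 3.0-fold higher number from compound 2 to compound 3 (0.48 log units; beyond the scatter) all involve the other end of the molecule, so they give no size for this change. Within the data shown here, compound 4 keeps the 2-carboxyethenyl group unchanged, so the only anchor is compound 1 at > 100000 nM, again a limit. No clear step is therefore expected in this assay, and a result reported only as a limit is quite possible. The expected step, very uncertain, is a number no higher from compound 1 to compound 4 (the limit leaves the size open). For compound 4 the estimated value is 100000 nM, with an expected range of 30000 nM to 300000 nM.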

Compound 4, half-maximal inhibitory concentration: > 100000 nM
Compound 4: only a limit was reported (the forecaster's own chance of this, stated with the estimate: 65%); the middle value lies on the limit itself.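

In this assay, compound 1 and compound 4 are each reported only as a limit, not a number, so no step between them can be read: the limit of > 100000 nM in this assay, at which 2 of the 4 values shown sit.

As far as these compounds go, whether hydrogen in place of hydroxy on the aromatic carbon changes inhibition at all remains open.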